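From Fluoro to Methyl on an Aromatic Carbon

The source may hold more compounds than are shown below. What is called first, only, known or untested is meant among the compounds shown, and "the series" means these compounds.

In an ADME assay on MT4 cells (Homo sapiens) for cytotoxicity, read by MTT assay, with a stated time of 5 days (on this read-out higher numbers stand for lower toxicity in this test and lower numbers for higher toxicity in this test), compound 1 `COc1cc(-c2ccc(C#N)cc2)ccc1[C@H](O)c1ccnc(Nc2ccc(C#N)cc2)n1`, which carries methoxy, gives 9070 nM. Compound 2 `N#Cc1ccc(Nc2nccc([C@@H](O)c3ccc(-c4ccc(C#N)cc4)cc3Cl)n2)cc1`, with chloro in place of methoxy, gives 4250 nM. Compound 3 `N#Cc1ccc(Nc2nccc([C@@H](O)c3ccc(-c4ccc(C#N)cc4)cc3F)n2)cc1`, with fluoro in place of methoxy, gives 7500 nM. Compound 3 stands within the scatter of both others, as the steps show: a 1.2-fold lower number from compound 1 to compound 3 (0.08 log units; within the scatter), and a 1.8-fold higher number from compound 2 to compound 3 (0.25 log units; within the scatter). Going by the values given here, the only step that clears the scatter is a modest one: a 2.1-fold lower number from compound 1 to compound 2 (0.33 log units; beyond the scatter).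

Compound 4 `Cc1cc(-c2ccc(C#N)cc2)ccc1[C@H](O)c1ccnc(Nc2ccc(C#N)cc2)n1` has not yet been measured. It differs from compound 3 by methyl in place of fluoro on an aromatic carbon. Among the compounds with values here, no measured compound shows this exact swap, so the three swaps above are the only guide. Even the largest of them, a 2.1-fold lower number from compound 1 to compound 2 (0.33 log units; beyond the scatter), is small, so no step beyond the scatter is expected here. The expected change is a 1.1-fold lower number from compound 3 to compound 4 (0.03 log units; within the scatter). In this assay the estimate for compound 4 is 7000 nM, with an estimated range of 3500 nM to 14000 nM.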

Compound 4, half-maximal cytotoxic concentration: 4000 nM
Compound 4: middle estimate off by 1.8-fold (0.24 log units), on the high side; the measured number falls inside the stated range.
By their numbers in this assay, from the lowest: compounds 4, 2, 3 and 1 (each within the scatter of the next, the first and the last beyond it).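

At this position on the shared core, methyl cannot be told apart from fluoro or chloro in this assay: the data show a 1.9-fold lower number from compound 3 to compound 4 (0.27 log units; within the scatter) and a 1.1-fold lower number from compound 2 to compound 4 (0.03 log units; within the scatter). Methyl differs from methoxy only modestly, with a 2.3-fold lower number from compound 1 to compound 4 (0.36 log units; beyond the scatter), so methoxy now stands beyond the scatter from both chloro and methyl, though not from fluoro, while fluoro stays within the scatter of all three other groups. Nothing available here explains these small differences.

As far as these compounds go, whether this narrow spread extends to groups of another kind, such as an amine, a carboxylic acid or a longer chain, remains open. So does whether any group at this position can move the number further than these four do.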